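Replacing the methoxyphenyl on the shared core of compound 2

The source may hold more compounds than are shown below. What is called first, only, known or untested is meant among the compounds shown, and "the series" means these compounds.

Compound 1 `CC(C)(C)n1ncc(OCc2nnc(-c3c(F)cccc3F)o2)c(Cl)c1=O` gives 45400 nM in a functional assay on the whole organism for inhibition, with Mythimna separata as the target, with a stated time of 5 days; on this read-out higher numbers stand for an effect only at larger amounts of compound and lower numbers for an effect already at smaller amounts. Among the measured compounds shown here, compound 2 `COc1ccc(-c2nnc(COc3cnn(C(C)(C)C)c(=O)c3Cl)o2)cc1` gives 17700 nM, the lowest of the two numbers, and the only known step is a 2.6-fold lower number from compound 1 to compound 2 (0.41 log units; beyond the scatter). Compound 3 `Cc1cccc(-c2nnc(COc3cnn(C(C)(C)C)c(=O)c3Cl)o2)c1` differs from compound 2 by 3-methylphenyl in place of 4-methoxyphenyl on an aromatic carbon. For the measured compounds named here, no measured step exchanges the methoxy for a methyl, so that step cannot be read from the data; a change no larger than the scatter is expected, with a 1.2-fold higher number from compound 2 to compound 3 (0.09 log units; within the scatter) as the estimated step. For compound 3 the estimate is 22000 nM, with a range from 8000 nM to 60000 nM.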

Compound 3, half-maximal effective concentration: 116000 nM
Compound 3: the middle estimate sits 5.3-fold (0.72 log units) below what was measured; the measured number lies above the stated range.
By their numbers in this assay, from the lowest: compound 2; then compound 1; then compound 3.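

In this assay the group at this position can move the read-out in either direction: 3-methylphenyl in place of 4-methoxyphenyl gives a 6.6-fold higher number from compound 2 to compound 3 (0.82 log units; beyond the scatter). 3-Methylphenyl in place of 2,6-difluorophenyl gives a 2.6-fold higher number from compound 1 to compound 3 (0.41 log units; beyond the scatter), which leaves compound 3 with the highest number of the three. Nothing available accounts for this rise. The step from compound 2 to compound 3 changes both the substituent and where it sits on the phenyl, and the two changes cannot be read apart. As far as these compounds go, how 4-methylphenyl, 3-methoxyphenyl or an unsubstituted phenyl would read remains open.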